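The compounds below may be only part of what the source reports. "The series", "measured", "known", "first", "only" and "open" are said of these compounds alone.

- Compound 1 (`COc1ccc(/C=C2\CN(C(=S)SCc3cn(Cc4ccc(F)cc4)nn3)C/C(=C\c3ccc(OC)cc3)C2=O)cc1`): 45600 nM
- Compound 2 (`Cc1ccc(/C=C2\CN(C(=S)SCc3cn(Cc4ccc(F)cc4)nn3)C/C(=C\c3ccc(C)cc3)C2=O)cc1`): 45500 nM

Among the compounds with values here, in a functional assay on PC-3 cells (Homo sapiens) for cytotoxicity, read by MTT assay, with a stated time of 24 h (a higher number here means a weaker inhibitor, a lower number a stronger inhibitor), compound 2 gives 45500 nM and stands within the scatter of compound 1, the only other compound measured. Compound 3 (`Cc1ccc(/C=C2\CN(C(=S)SCc3cn(Cc4ccccc4F)nn3)C/C(=C\c3ccc(C)cc3)C2=O)cc1`) has 2-fluorophenyl in place of 4-fluorophenyl on a saturated chain carbon bound to an aromatic nitrogen. Within the data shown here, no measured pair tests this change, so no step beyond the scatter is expected in this assay here. The expected result is a small estimated step (a 1.1-fold lower number from compound 2 to compound 3 (0.03 log units; within the scatter)) that stays within the scatter. For compound 3 the estimated value is 42000 nM with 22000 nM to 80000 nM as its range.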

Compound 3, half-maximal inhibitory concentration: > 80000 nM
Compound 3 was reported as a limit (the forecaster's own chance of this, stated with the estimate: 5%); middle value at least 1.9-fold (0.27 log units) from the limit.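

Compound 1 and compound 2 both carry 4-fluorobenzyl, so they said nothing about this position. In this assay compound 3 gives > 80000 nM, which is a limit of the assay and not a number. Exchanging 4-fluorobenzyl for 2-fluorobenzyl, with the same atoms joined differently, gives an at least 1.7-fold higher number from compound 2 to compound 3 (0.24 log units; that floor lies within the scatter), so this first test of the fluorine's placement shows no firm loss, though the true gap may be larger. As far as these compounds go, how a plain benzyl or a 4-chlorobenzyl would read at this place remains open. So does the true value of compound 3.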